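This account rests on a few compounds, and the source may have more. Where it says the series, first, only, none or still open, it means among the compounds named here.

Among the measured compounds shown here, compound 1, `CNC(=O)C#Cc1ccc(NC(=O)Nc2ccc(Cl)c(C(F)(F)F)c2)cc1`, is the only compound with a firm number: in a functional assay on KETR3 cells (Homo sapiens) for inhibition, read by MTT assay, with a stated time of 120 h (a higher number here means a weaker inhibitor, a lower number a stronger inhibitor), compound 1 gives 24700 nM. Compound 2, `O=C(CCc1ccc(NC(=O)Nc2ccc(Cl)c(C(F)(F)F)c2)cc1)NC1CCC1`, in this assay reaches only the limit > 50000 nM. The step of an at least 2.0-fold higher number from compound 1 to compound 2 (0.30 log units; that floor lies within the scatter) puts 2-(cyclobutylcarbamoyl)ethyl in place of 2-(methylcarbamoyl)ethynyl on an aromatic carbon, and the limit of > 50000 nM in this assay, at which 1 of the 2 values shown sits, shows where that value ends. Compound 3, `CC(NC(=O)C#Cc1ccc(NC(=O)Nc2ccc(Cl)c(C(F)(F)F)c2)cc1)c1ccccc1`, differs from compound 1 by 1-phenylethyl in place of methyl on an amide-type nitrogen. For the measured compounds named here, the single measured step alters both the chain and the group on the amide-type nitrogen at once, so it bears only loosely on this change; it does show that enlarging the group on that nitrogen did not, in that case, yield a stronger inhibitor. The expected step is therefore a 1.4-fold lower number from compound 1 to compound 3 (0.14 log units; within the scatter), modest against the scatter. Compound 3 is estimated at 18000 nM in this assay, between 5000 nM and 50000 nM.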

Compound 3, half-maximal inhibitory concentration: 21400 nM
Estimate against measurement, compound 3: 1.2-fold (0.08 log units) below; measured number inside the range.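

On the amide-type nitrogen, 1-phenylethyl in place of methyl gives a 1.2-fold lower number from compound 1 to compound 3 (0.06 log units; within the scatter) in this assay, so the two compounds cannot be told apart there. Among the compounds shown here, this is the first comparison that changes only this group: 8 heavy atoms and a six-membered aromatic ring enter where a single carbon stood, and the number stays within the usual scatter of repeated measurements. No measurement shown gives a reason for this result.

The compounds shown leave open what a group carrying an amine or a carboxylic acid would do on that same nitrogen. Compound 2 reaches only a limit, > 50000 nM, and it remains open which of its two changes, the ethyl chain or the cyclobutyl group, lies behind it.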